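Methoxyphenyl position change on two related cores

This account rests on a few compounds, and the source may have more. Where it says the series, first, only, none or still open, it means among the compounds named here.

Measured in a functional assay on HCT-116 cells (Homo sapiens) for inhibition, read by sulforhodamine B assay, with a stated time of 48 h, tested at 50 uM; a lower number here means less inhibition of growth, a higher number more inhibition of growth at the concentration tested:
compound 1, `COc1ccc(/C=C/C(=O)/C=C/c2ccc(OCc3cn(CCCCCOc4cc(=O)oc5ccccc45)nn3)c(OC)c2)cc1`: compound 1 gives 35%
compound 2, `COc1ccccc1/C=C/C(=O)/C=C/c1ccc(OCc2cn(CCCCCOc3cc(=O)oc4ccccc34)nn2)c(OC)c1`: compound 2 gives 33%
compound 3, `COc1ccccc1/C=C/C(=O)/C=C/c1ccc(OCc2cn(CCOc3cc(=O)oc4ccccc34)nn2)c(OC)c1`: compound 3 gives 70%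

Compound 2 and compound 1 share a core and differ only by 4-methoxyphenyl in place of 2-methoxyphenyl on a double-bonded chain carbon bound to a double-bonded chain carbon. The step of a number 2 percentage points higher from compound 2 to compound 1 (within the scatter) lies within the scatter, so the two values cannot be ordered. Compound 3 carries a different core; how the core of compound 3 differs from the core of compound 2 is not broken down here. Compound 3 stands highest of the three, beyond the scatter against both compound 1 and compound 2.

Compound 4, `COc1ccc(/C=C/C(=O)/C=C/c2ccc(OCc3cn(CCOc4cc(=O)oc5ccccc45)nn3)c(OC)c2)cc1`, is not yet measured. It differs from compound 3 by 4-methoxyphenyl in place of 2-methoxyphenyl on a double-bonded chain carbon bound to a double-bonded chain carbon, the same change as from compound 2 to compound 1, at the same place. Because a number 2 percentage points higher from compound 2 to compound 1 (within the scatter) was within the scatter, the expected step of no change at the digits printed from compound 3 to compound 4 (within the scatter) in this assay is also small. Compound 4 is therefore expected to give 70%, between 55% and 82%, resting on compound 3 giving 70%.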

Compound 4, percent growth inhibition at one concentration: 71%
Estimate against measurement, compound 4: 1 percentage points below; the measured number falls inside the stated range.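

In this assay, 4-methoxyphenyl in place of 2-methoxyphenyl gives a number 1 percentage points higher from compound 3 to compound 4 (within the scatter). Set beside the earlier step, the same change reads alike on the two cores: the same change on two cores in this assay, a number 2 percentage points higher (within the scatter) from compound 2 to compound 1 and a number 1 percentage points higher (within the scatter) from compound 3 to compound 4, 1 percentage points apart, within the scatter of two such steps

For the compounds shown here, on these two cores, the exchange therefore leaves no step that can be told from the scatter, so carrying it from one core to the other holds up here, but only for this pair of groups, at this place, in this one assay at a single concentration; it does not show that the two groups are interchangeable on any further core or in any other read-out.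

The compounds shown leave open whether a phenyl ring bearing an amine or a carboxylic acid, set on a double-bonded chain carbon bound to a double-bonded chain carbon, would give a step beyond the scatter in this assay. They also leave open whether the same exchange stays this small on a core with a longer chain.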